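Benzyl replacement on the oxadiazole: compound 3 to compound 4

This account rests on a few compounds, and the source may have more. Where it says the series, first, only, none or still open, it means among the compounds named here.

Measured compounds:
compound 1 `CCc1ccccc1N(Cc1nnc(Cc2ccccc2)o1)S(=O)(=O)c1ccc(C)cc1`: 398 nM
compound 2 `CCOc1ccc(Cc2nnc(CN(c3cccc(Cl)c3Cl)S(=O)(=O)c3ccc(C)cc3)o2)cc1`: 31.6 nM
compound 3 `Cc1ccc(S(=O)(=O)N(Cc2nnc(Cc3ccc(C(F)(F)F)cc3)o2)c2cccc(Cl)c2C)cc1`: 158 nM

In a functional assay on CHO cells for antagonist activity at prostaglandin E2 receptor EP1 subtype (Homo sapiens), read by FLIPR and calcium flux (on this read-out lower numbers stand for stronger inhibition and higher numbers for weaker inhibition), compound 3 gives 158 nM and stands second highest of the three numbers. Its nearest neighbour is compound 1, whose value in this assay is 398 nM, a step beyond the scatter; the furthest is compound 2, which in this assay gives 31.6 nM, also beyond the scatter. None of these three pairs differs in a single place, so their values are read side by side only.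

Compound 4 `Cc1ccc(S(=O)(=O)N(Cc2nnc(Cc3c(Cl)cccc3Cl)o2)c2cccc(Cl)c2C)cc1` is not yet measured. It differs from compound 3 in one place: 2,6-dichlorophenyl in place of 4-(trifluoromethyl)phenyl on a saturated chain carbon bound to an aromatic carbon. For the measured compounds named here, no measured pair tells how this exchange of one aryl group for another on that benzyl carbon plays out; the three measured compounds all carry different groups elsewhere as well. The expectation is therefore cautious: the step of a 1.2-fold lower number from compound 3 to compound 4 (0.08 log units; within the scatter) is expected to be small, in either direction, and most likely not beyond the scatter. For compound 4 in this assay a value of 130 nM is estimated, within a range from 40 nM to 420 nM.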

Compound 4, inhibition constant: 501 nM
The estimate for compound 4 lay 3.9-fold (0.59 log units) below the measured number, and the stated range ends below it.
By their numbers in this assay, from the lowest: compound 2; then compound 3; then compounds 1 and 4 (each within the scatter of the next).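

In this assay, the exchange of 4-(trifluoromethyl)phenyl for 2,6-dichlorophenyl on a saturated chain carbon bound to an aromatic carbon gives the first single-place comparison among these compounds (a 3.2-fold higher number from compound 3 to compound 4 (0.50 log units; beyond the scatter)). It shows that this position is not indifferent to the substitution of its aryl group, and that the number rises here. The step arises although both groups have one six-membered aromatic ring of carbon only, no hydrogen-bond donors or acceptors and no net charge, and differ only in their substituents and heavy-atom count.

This single pair cannot separate the effect of the halogen from that of the substitution pattern, and it leaves open how an amine or a carboxylic acid on that aryl group would read out. Nothing in the available data accounts for the size or direction of this step.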